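A few compounds are considered here, and "the series" means these few. Any claim that something is new, unique, unknown or untested is made for them only; others in the source may bear on it.

Of the compounds shown here, three have so far been measured in a functional assay on the whole organism (strain CF-1) for inhibition, with Mus musculus as the target; on this read-out higher numbers stand for an effect only at larger amounts of compound and lower numbers for an effect already at smaller amounts. Compound 1 `Cc1nnc(CN(C)C)n1-c1ccc(Cl)cc1C(=O)c1ccccc1` gives 1.1 mg/kg. Compound 2 `CN(C)CCn1nc(CN(C)C)n(-c2ccc(Cl)cc2C(=O)c2ccccc2)c1=O` gives 18 mg/kg. Compound 3 `Cc1nnc(CN2CCCC2)n1-c1ccc(Cl)cc1C(O)c1ccccc1` gives 14 mg/kg, the second highest of the three numbers; it sits within the scatter of compound 2, while compound 1 lies well below it, beyond the scatter.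

Compound 4 `Cc1nnc(CN2CCCC2)n1-c1ccc(Cl)cc1C(=O)c1ccccc1Cl` has not yet been measured in this assay. It differs from compound 3 in one place: (2-chlorophenyl)carbonyl in place of hydroxy(phenyl)methyl on an aromatic carbon. Among the compounds with values here, no measured pair isolates this change. Compound 1, which also carries a carbonyl at that position, gives 1.1 mg/kg, whereas compound 3 with its hydroxy(phenyl)methyl gives 14 mg/kg; the two differ elsewhere too, so the comparison is loose. The step expected is a 4.7-fold lower number from compound 3 to compound 4 (0.67 log units; beyond the scatter), toward lower numbers, because compound 1 with its carbonyl gives 1.1 mg/kg. Compound 4 is therefore estimated at 3 mg/kg, with a range from 1 mg/kg to 10 mg/kg.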

Compound 4, dose for half-maximal effect: 4 mg/kg
Beside the measured number, compound 4's estimate is 1.3-fold (0.12 log units) below it; measured number inside the range.
By their numbers in this assay, from the lowest: compound 1; then compound 4; then compounds 3 and 2 (each within the scatter of the next).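

Within the data shown here, at this position, on an aromatic carbon, this assay gives the first direct reading of the change: (2-chlorophenyl)carbonyl in place of hydroxy(phenyl)methyl brings a 3.5-fold lower number from compound 3 to compound 4 (0.54 log units; beyond the scatter), a step that is modest in size but beyond the usual scatter. The exchange alters two things at once, since the hydroxy-bearing carbon gives way to a carbonyl, with the loss of the hydrogen-bond donor, and a chlorine enters on the phenyl ring, so this single step cannot be divided between them. Nothing at hand explains why the number falls.

The compounds shown leave open what hydroxy(2-chlorophenyl)methyl would give at this place on the core of compound 3, a group that would separate the chlorine from the carbonyl. Going by these compounds, how a fluorine or a methyl in place of that chlorine would read also remains open.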